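Phenoxy replaced on an aromatic carbon: expectation for compound 3

This account rests on a few compounds, and the source may have more. Where it says the series, first, only, none or still open, it means among the compounds named here.

Measured so far in a functional assay for inhibition of sodium/hydrogen exchanger (Oryctolagus cuniculus); on this read-out higher numbers stand for weaker inhibition and lower numbers for stronger inhibition:
compound 1 `Cc1cc(OC(C)C)c(S(C)(=O)=O)cc1C(=O)N=C(N)N`: 19 nM
compound 2 `Cc1cc(Oc2ccccc2)c(S(C)(=O)=O)cc1C(=O)N=C(N)N`: 10 nM

Within the data shown here, the single measured step, a 1.9-fold lower number from compound 1 to compound 2 (0.28 log units; within the scatter), puts phenyl in place of isopropyl on an oxygen on an aromatic ring. Of the two numbers in hand, that of compound 2 is the smaller, but its step from compound 1 lies within the scatter, so the two compounds are not distinguished by this assay.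

Compound 3 `Cc1cc(-n2ccc(=O)cc2)c(S(C)(=O)=O)cc1C(=O)N=C(N)N` is not yet measured. It differs from compound 2 as follows: a group of 7 heavy atoms (5 carbon, 1 nitrogen, 1 oxygen; one six-membered aromatic ring with 1 hetero atom) in place of a group of 7 heavy atoms (6 carbon, 1 oxygen; one six-membered aromatic ring of carbon only), on an aromatic carbon. Among the measured compounds shown here, no measured step bears directly on this change; the only step in hand concerns the group on the oxygen and was itself within the scatter. What the numbers do show is that compound 2 carries an aromatic ring on this aromatic carbon without a step beyond the scatter from compound 1. From the compounds shown here alone, compound 3 is therefore expected to stay near compound 2, with an estimated step of a 1.5-fold higher number from compound 2 to compound 3 (0.18 log units; within the scatter), the range kept wide since the entering group is untested. The estimate for compound 3 in this assay is 15 nM, between 5 nM and 60 nM.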

Compound 3, half-maximal inhibitory concentration: 75 nM
For compound 3 the middle estimate is 5.0-fold (0.70 log units) below the measured one; the whole stated range lies below it.
By their numbers in this assay, from the lowest: compounds 2 and 1 (each within the scatter of the next); then compound 3.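

In this assay, this aromatic carbon, ortho to a methylsulfonyl group, does not treat every group bearing a six-membered aromatic ring alike: replacing phenoxy with a group of the same heavy-atom count, whose ring has 1 hetero atom, gives a 7.5-fold higher number from compound 2 to compound 3 (0.88 log units; beyond the scatter). Heavy-atom count and the presence of an aromatic ring therefore do not alone set the number at this position, and the entering group also separates from the isopropyl ether, with a 3.9-fold higher number from compound 1 to compound 3 (0.60 log units; beyond the scatter). So, while the two oxygen-linked groups of compound 1 and compound 2 are not distinguished by this read-out, compound 3 stands apart from both, and no measurement at hand accounts for that difference.

From the compounds shown here alone, the change to compound 3 alters the link to the core and the ring together, so it remains open whether the higher number goes with losing the ether oxygen or with the ring nitrogen and carbonyl. A phenyl group directly on the aromatic carbon and a pyridyloxy group would take those two parts apart.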